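The source may report more compounds than this note shows. Statements on the series, on what has been measured and on what is new or still open speak of the compounds shown alone.

Three compounds share a common core and differ only in the group carried on the five-membered ring with three nitrogens. In a functional assay on HCC827 cells (Homo sapiens) for antiproliferative activity, read by sulforhodamine B assay, with a stated time of 72 h (on this read-out lower numbers stand for stronger inhibition and higher numbers for weaker inhibition), compound 1 `CN(CCNCc1cn(-c2ccccc2)nn1)CCNc1ccnc2cc(Cl)ccc12` gives 26000 nM, compound 2 `CN(CCNCc1cn(-c2ccc(F)cc2)nn1)CCNc1ccnc2cc(Cl)ccc12` gives 19000 nM, and compound 3 `CN(CCNCc1cn(Cc2ccc(Br)cc2)nn1)CCNc1ccnc2cc(Cl)ccc12` gives 9300 nM. Compound 3 therefore stands lowest of the three on this assay, its nearest neighbour being compound 2 and its furthest compound 1.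

Compound 4 `CN(CCNCc1cn(-c2ccnc3cc(Cl)ccc23)nn1)CCNc1ccnc2cc(Cl)ccc12` takes this series one step further: 7-chloroquinolin-4-yl in place of 4-bromobenzyl on an aromatic nitrogen. Among the compounds with values here, no measured step involves a group of this kind, so the only guidance is indirect. The steps of a 2.8-fold lower number from compound 1 to compound 3 (0.45 log units; beyond the scatter) and a 2.0-fold lower number from compound 2 to compound 3 (0.31 log units; beyond the scatter) show that exchanging the group on this ring nitrogen shifts this assay by modest amounts, not large ones. A comparable or slightly larger shift in the same direction is expected here, with considerable uncertainty.

Compound 4 is thus estimated at 6000 nM, within a range of 2000 nM to 20000 nM, which corresponds to an expected step of a 1.6-fold lower number from compound 3 to compound 4 (0.19 log units; within the scatter).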

Compound 4, half-maximal inhibitory concentration: 18000 nM
Beside the measured number, compound 4's estimate is 3.0-fold (0.48 log units) below it, and the stated range covers the measured number.
By their numbers in this assay, from the lowest: compounds 3, 4, 2 and 1 (each within the scatter of the next, the first and the last beyond it).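

On this assay, the 7-chloroquinolin-4-yl group, which brings a second aromatic ring and a hydrogen-bond acceptor to this ring nitrogen, cannot be separated from any of the three earlier groups: there is a 1.9-fold higher number from compound 3 to compound 4 (0.29 log units; within the scatter), a 1.1-fold lower number from compound 2 to compound 4 (0.02 log units; within the scatter), and a 1.4-fold lower number from compound 1 to compound 4 (0.16 log units; within the scatter). This position therefore takes this much larger group with no step beyond the scatter, and the lead of compound 3, clear over compound 1 and compound 2, does not extend clearly to compound 4. No measured finding bears on why this is so.

The compounds shown leave open whether a plain benzyl group without bromine would match the 4-bromobenzyl group. They also leave open how this assay would respond to an amine or a carboxylic acid on the group at this ring nitrogen.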